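The source may hold more compounds than are shown below. What is called first, only, known or untested is meant among the compounds shown, and "the series" means these compounds.

Compound 2 `CCCCOc1ccc(C(O)C2OC(=O)c3c(OC)cc(OC)cc32)cc1` holds the lowest number among the three measured in a functional assay on RAW264.7 cells (Mus musculus) for inhibition, read by Griess assay, with stated times of 1 h and 24 h; a lower number here means a stronger inhibitor, a higher number a weaker inhibitor: compound 2 gives 1800 nM. Compound 1 `CCCOc1ccc(C(O)C2OC(=O)c3c(OC)cc(OC)cc32)cc1` gives 9260 nM, and compound 3 `COc1cc(OC)c2c(c1)C(C(O)c1ccc(OCc3ccc(Cl)cc3)cc1)OC2=O` gives 4320 nM. The measured steps are all modest: a 5.1-fold lower number from compound 1 to compound 2 (0.71 log units; beyond the scatter), a 2.1-fold lower number from compound 1 to compound 3 (0.33 log units; beyond the scatter) and a 2.4-fold higher number from compound 2 to compound 3 (0.38 log units; beyond the scatter).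

Compound 4 `COc1cc(OC)c2c(c1)C(C(O)c1ccc(OCc3ccc(Br)cc3)cc1)OC2=O` has not yet been measured in this assay. It differs from compound 2 in one place: 4-bromophenyl in place of propyl on a saturated chain carbon bound to an oxygen on an aromatic ring. Going by the values given here, the step that bears directly on this is the one from compound 2 to compound 3, which is the same exchange at the same place, with 4-chlorophenyl entering rather than 4-bromophenyl; in this assay it gave a 2.4-fold higher number from compound 2 to compound 3 (0.38 log units; beyond the scatter). Among the compounds with values here, no other measured pair addresses a swap of this kind. A step of comparable size, toward a higher number, is therefore expected from compound 2 to compound 4, namely a 2.4-fold higher number from compound 2 to compound 4 (0.38 log units; beyond the scatter). Compound 4 is accordingly estimated to give 4300 nM in this assay, expected to fall between 2000 nM and 9500 nM.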

Compound 4, half-maximal inhibitory concentration: 6530 nM
Compound 4: the middle estimate sits 1.5-fold (0.18 log units) below what was measured; measured number inside the range.
By their numbers in this assay, from the lowest: compound 2; then compounds 3, 4 and 1 (each within the scatter of the next, the first and the last beyond it).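

In this assay, butyl to 4-bromobenzyl gives a 3.6-fold higher number from compound 2 to compound 4 (0.56 log units; beyond the scatter), so the loss first seen with compound 3 recurs with a second halogen, and no compound shown goes against this. Bromo in place of chloro on an aromatic carbon gives a 1.5-fold higher number from compound 3 to compound 4 (0.18 log units; within the scatter), so the two halogens are not told apart at this position. Going by these compounds alone, the comparison with the shorter chain also gives no separation, with a 1.4-fold lower number from compound 1 to compound 4 (0.15 log units; within the scatter), which leaves butyl in compound 2 as the only group here clearly ahead of compound 4.

Going by these compounds, whether a longer chain such as pentyl or hexyl, or an unsubstituted benzyl or 4-methoxybenzyl, on the oxygen on an aromatic ring would improve on compound 2 remains open. No measured evidence accounts for these differences.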